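The compounds below may be only part of what the source reports. "The series", "measured", "known", "first", "only" and "open" are said of these compounds alone.

Compound 1 `CN(C)C1(Cc2ccccc2)CCN(c2cc(C(F)(F)F)ccc2CNC(=O)Nc2ccc(CNS(C)(=O)=O)c(F)c2)CC1` gives 25 nM in an assay on CHO cells for antagonist activity at transient receptor potential cation channel subfamily V member 1 (Homo sapiens), read by scintillation counting, with a stated time of 5 min, in the presence of a further agent that is not named here; a higher number here means that more compound is needed for the effect, a lower number that less compound is needed.
Compound 2 `CN(C)C1(Cc2ccccc2)CCN(c2cc(C(F)(F)F)ccc2CNC(=O)Nc2ccc(CNS(N)(=O)=O)c(F)c2)CC1` gives 120 nM in the same assay.
Compound 3 `CN(C)C1(Cc2ccccc2)CCN(c2cc(C(F)(F)F)ccc2CNC(=O)Nc2cccc3c2CC(O)CC3)CC1` gives 10.1 nM in the same assay.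

Of the three measured compounds, compound 3 stands at the lowest number, meaning the least compound is needed for the effect; compound 1 sits above it and compound 2 higher still. All three share the same core, and they differ only in the group attached to the urea nitrogen furthest from that core.

For the measured compounds named here, the one step measured so far, a 4.8-fold higher number from compound 1 to compound 2 (0.68 log units; beyond the scatter), changes a group on the sulfonyl sulfur, a part of the molecule that is absent from compound 3. It therefore says nothing directly about the change at hand, which is isoquinolin-7-yl in place of 3-hydroxy-1,2,3,4-tetrahydronaphthalen-5-yl on an amide-type nitrogen, giving compound 4 `CN(C)C1(Cc2ccccc2)CCN(c2cc(C(F)(F)F)ccc2CNC(=O)Nc2ccc3ccncc3c2)CC1`. Going by the values given here, the data hold no step in which a hydroxy-bearing saturated ring is traded for a nitrogen-containing aromatic ring, so the expectation rests only on the starting point. Among the compounds with values here, with no guiding step, a modest move toward a higher number is expected, a 2.0-fold higher number from compound 3 to compound 4 (0.30 log units; within the scatter), though a result within the scatter of compound 3 would not surprise.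

Compound 4 is estimated to give 20 nM, with a likely range from 5 nM to 80 nM.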

Compound 4, half-maximal effective concentration: 56.1 nM
Compound 4: middle estimate off by 2.8-fold (0.45 log units), on the low side; low and high end bracket the measured number.
By their numbers in this assay, from the lowest: compound 3; then compound 1; then compound 4; then compound 2.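

In this assay, placing isoquinolin-7-yl instead of 3-hydroxy-1,2,3,4-tetrahydronaphthalen-5-yl on the amide-type nitrogen gives a 5.6-fold higher number from compound 3 to compound 4 (0.74 log units; beyond the scatter) and so shows that the number responds to the group at this place, a point the sulfonyl step could not address. For this pair, the fully aromatic group with a ring nitrogen needs more compound than the hydroxy-bearing group with a non-aromatic ring. Several things change together in this one step, including the loss of the oxygen, the gain of the ring nitrogen, the change from a non-aromatic to an aromatic ring, and the move from 1 hydrogen-bond donor to 0, and nothing measured here explains the rise or assigns it to any one of these changes.

The compounds shown leave open whether the hydroxy group itself matters, which an amine or a methoxy group in its place on the same non-aromatic ring could begin to test. They also leave open what the ring nitrogen of isoquinolin-7-yl contributes, which a matching group with a carbon in place of that nitrogen could separate from the effect of the aromatic ring.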